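This account rests on a few compounds, and the source may have more. Where it says the series, first, only, none or still open, it means among the compounds named here.

Three compounds built on one shared core were measured in a functional assay on isolated protein for inhibition of Glucose-dependent insulinotropic receptor (Rattus norvegicus), read by HTRF and cAMP accumulation (on this read-out lower numbers stand for smaller maximal responses and higher numbers for larger maximal responses), and they differ only in the group carried on a carbonyl carbon whose other neighbour is an amide-type nitrogen in a ring. Compound 1 `Cc1nc(S(C)(=O)=O)ccc1Oc1ncnc(OC2CCN(C(=O)O[C@H](C)CF)CC2)c1F` gives 79% in this assay, compound 2 `Cc1nc(S(C)(=O)=O)ccc1Oc1ncnc(OC2CCN(C(=O)OC3COC3)CC2)c1F` gives 66%, and compound 3 `Cc1nc(S(C)(=O)=O)ccc1Oc1ncnc(OC2CCN(C(=O)C(F)(F)F)CC2)c1F` gives 76%. Of the three steps between them, a number 13 percentage points lower from compound 1 to compound 2 (beyond the scatter) lies beyond the scatter, whereas a number 3 percentage points lower from compound 1 to compound 3 (within the scatter) and a number 10 percentage points higher from compound 2 to compound 3 (within the scatter) both lie within it. On the numbers shown, compound 3 stands second highest of the three, although its gaps to compound 1 and to compound 2 are both within the usual scatter of repeated measurements.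

Compound 4 `Cc1nc(S(C)(=O)=O)ccc1Oc1ncnc(OC2CCN(C(=O)C(C)(C)F)CC2)c1F` has not yet been measured in this assay. Compared with compound 3 it carries 1-fluoro-1-methylethyl in place of trifluoromethyl on a carbonyl carbon. Going by the values given here, the steps that bear on this change are the two that also replace the group on the carbonyl carbon, a number 3 percentage points lower from compound 1 to compound 3 (within the scatter) and a number 10 percentage points higher from compound 2 to compound 3 (within the scatter), and neither of them left the scatter. The expected step is therefore small, a number 1 percentage points lower from compound 3 to compound 4 (within the scatter), with no clear direction beyond the scatter. Compound 4 is estimated at 75%, within a range from 62% to 88%.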

Compound 4, largest response reached (reported as efficacy), in percent of the reference or control that the assay uses: 74%
Compound 4: the middle estimate sits 1 percentage points above what was measured, within the range that was stated.
By their numbers in this assay, from the lowest: compounds 2, 4, 3 and 1 (each within the scatter of the next, the first and the last beyond it).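

In this assay, going by these compounds alone, exchanging trifluoromethyl for 1-fluoro-1-methylethyl on a carbonyl carbon whose other neighbour is an amide-type nitrogen in a ring gives a number 2 percentage points lower from compound 3 to compound 4 (within the scatter), so this change of group, at an equal count of heavy atoms, produces no step that can be told from the scatter. The new compound also stands within the scatter of both earlier compounds that carry an oxygen-linked group at this place, with a number 8 percentage points higher from compound 2 to compound 4 (within the scatter) and a number 5 percentage points lower from compound 1 to compound 4 (within the scatter), even though those two are themselves separated by a number 13 percentage points lower from compound 1 to compound 2 (beyond the scatter). Within the data shown here, compound 3 was the only example with a carbon-linked group here until now, and compound 3 and compound 4 together show that two different carbon-linked groups read alike in this assay, leaving the one step beyond the scatter to the pair of compound 1 and compound 2.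

Nothing in the material shown explains these results. All the groups at this place in compound 1, compound 3 and compound 4 carry fluorine, so the compounds leave open whether a fluorine-free group such as tert-butyl, or an amine on the carbonyl carbon, would keep the maximal response in this range.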